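Amide side-chain variation within the shared core series

The source may hold more compounds than are shown below. What is called first, only, known or untested is meant among the compounds shown, and "the series" means these compounds.

compound 1 `CCCCNC(=O)C1CCN(c2nc(N)c3cc(OC)c(OC)cc3n2)CC1`: 0.67 nM
compound 2 `COc1cc2nc(N3CCC(C(=O)NCc4ccccc4)CC3)nc(N)c2cc1OC`: 0.22 nM

In an assay on isolated protein for displacement of a labelled ligand from Adrenergic receptor alpha-1 (Rattus norvegicus) (on this read-out lower numbers stand for stronger inhibition and higher numbers for weaker inhibition), compound 2 gives the lowest of the two numbers, with compound 1 the nearest. Compound 3 `COc1cc2nc(N3CCC(CC(=O)NCC4CC4)CC3)nc(N)c2cc1OC` carries ((cyclopropylmethyl)carbamoyl)methyl in place of benzylcarbamoyl on a saturated ring carbon. For the measured compounds named here, the only measured step that bears on this change is a 3.0-fold lower number from compound 1 to compound 2 (0.48 log units; beyond the scatter), in which an aromatic ring in place of a chain gave the stronger number; compound 3 moves the other way, toward a small saturated ring on a chain, so a modest rise in the number is expected, a 2.5-fold higher number from compound 2 to compound 3 (0.40 log units; beyond the scatter). For compound 3 the estimate is 0.55 nM, within a range of 0.2 nM to 1.5 nM.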

Compound 3, inhibition constant: 1.08 nM
Compound 3: the middle estimate sits 2.0-fold (0.29 log units) below what was measured; low and high end bracket the measured number.
By their numbers in this assay, from the lowest: compound 2; then compounds 1 and 3 (each within the scatter of the next).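

In this assay, ((cyclopropylmethyl)carbamoyl)methyl does not keep the number reached with benzylcarbamoyl on this saturated ring carbon, giving a 4.9-fold higher number from compound 2 to compound 3 (0.69 log units; beyond the scatter). Set against the butylcarbamoyl group, the same change gives a 1.6-fold higher number from compound 1 to compound 3 (0.21 log units; within the scatter), so among these compounds only the benzylcarbamoyl of compound 2 stands apart. No available evidence accounts for this result.

The step changes both the link to the carbonyl and the group on the amide nitrogen, and their shares remain unresolved. A (benzylcarbamoyl)methyl group at this position would separate the two.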